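Methylation of a Trihydroxyphenyl Hydrazone: What to Expect

This account rests on a few compounds, and the source may have more. Where it says the series, first, only, none or still open, it means among the compounds named here.

Measured compounds:
compound 1, `O=C(CCc1nc2ccccc2c(=O)[nH]1)N/N=C/c1ccc(O)cc1`, gives 105000000 nM in a physicochemical assay, read by spectrophotometry, with a stated time of 6 min; a higher number here means a weaker inhibitor, a lower number a stronger inhibitor
compound 2, `COc1ccc(/C=N/NC(=O)CCc2nc3ccccc3c(=O)[nH]2)cc1`, gives 75000000 nM in this assay
compound 3, `O=C(CCc1nc2ccccc2c(=O)[nH]1)N/N=C/c1cc(O)c(O)c(O)c1`, gives 35000000 nM in this assay

The three measured compounds share a common core and differ only in the aromatic ring attached to the carbon with a double bond to nitrogen. Compound 3 differs from compound 1 by 3,4,5-trihydroxyphenyl in place of 4-hydroxyphenyl on a carbon with a double bond to nitrogen, and this gave a 3.0-fold lower number from compound 1 to compound 3 (0.48 log units; beyond the scatter). Compound 2 differs from compound 1 by methyl in place of hydrogen on an oxygen on an aromatic ring, a step of a 1.4-fold lower number from compound 1 to compound 2 (0.15 log units; within the scatter), so the added methyl made no difference that can be trusted. Between compound 2 and compound 3 the step was a 2.1-fold lower number from compound 2 to compound 3 (0.33 log units; beyond the scatter).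

Compound 4, `COc1cc(/C=N/NC(=O)CCc2nc3ccccc3c(=O)[nH]2)cc(O)c1O`, is not yet measured. It differs from compound 3 by methyl in place of hydrogen on an oxygen on an aromatic ring, the same change already seen from compound 1 to compound 2, placed on the same kind of oxygen; the cores on which the change sits differ as described by 3,4,5-trihydroxyphenyl in place of 4-hydroxyphenyl on a carbon with a double bond to nitrogen.

Because a 1.4-fold lower number from compound 1 to compound 2 (0.15 log units; within the scatter) stayed within the scatter, the expected step from compound 3 to compound 4 in this assay is also small, about a 1.3-fold lower number from compound 3 to compound 4 (0.10 log units; within the scatter). Compound 4 is therefore estimated at 28000000 nM, with a likely range from 12000000 nM to 70000000 nM.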

Compound 4, half-maximal inhibitory concentration: 40000000 nM
For compound 4 the middle estimate is 1.4-fold (0.15 log units) below the measured one; the range from low to high includes it.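

Swapping the hydrogen for a methyl on an oxygen on an aromatic ring, turning hydroxy into methoxy, gave a 1.1-fold higher number from compound 3 to compound 4 (0.06 log units; within the scatter) in this assay, and the same swap on the other core gave a 1.4-fold lower number from compound 1 to compound 2 (0.15 log units; within the scatter); both steps lie within the scatter, so on each of these two cores the change made no difference that can be trusted, and the earlier result carried over to the new core in that sense. Among the compounds shown here, this does not show that the change is without effect on every core, since only two pairs are available, and neither small step can be given a reliable direction. Nothing shown here explains why the methyl left the number so little changed, as no separate measurement bears on that question.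

Still open, as far as these compounds go, is whether a larger group on the same oxygen, such as ethyl or a longer chain, would give a step beyond the scatter, and the same applies to an amine or a carboxylic acid in place of the hydroxy. Also open, from the compounds shown here alone, is what would follow from placing methyl on more than one oxygen of the 3,4,5-trihydroxyphenyl group.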